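One Ring Swapped in a Compound at the Assay Limit

The source may report more compounds than this note shows. Statements on the series, on what has been measured and on what is new or still open speak of the compounds shown alone.

Going by the values given here, only two compounds have been measured so far in a functional assay on the whole organism for agonist activity, with Mus musculus as the target; a higher number here means that more compound is needed for the effect, a lower number that less compound is needed. Compound 1 (`CC(=O)N(C)C(C)C#CCn1cncc1C`) gives > 100 mg/kg, which is a limit of the assay and not a number. Compound 2 (`CCOC(=O)N(C)C(C)C#CCN1CCCC1`) gives > 100 mg/kg, which is likewise only a limit. That is the whole picture so far: the limit of > 100 mg/kg in this assay, at which 2 of the 2 values shown sit. Compound 2 therefore has no exact position on the scale.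

Compound 3 (`CCOC(=O)N(C)C(C)C#CCn1cncc1C`) differs from compound 2 at one place, with 5-methyl-1H-imidazol-1-yl in place of pyrrolidin-1-yl on a saturated chain carbon bound to a triple-bonded carbon. Among the compounds with values here, no measured pair shows what this change does on its own. The best available hint is compound 1, which already carries 5-methyl-1H-imidazol-1-yl and reads > 100 mg/kg, a limit. The expected size of the change in this assay is a step that the limit leaves unreadable from compound 2 to compound 3, with no real gain in potency anticipated. For compound 3 the estimated dose is 150 mg/kg, with an expected range of 60 mg/kg to 400 mg/kg, and a reading at the limit is the likeliest outcome.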

Compound 3, dose for half-maximal effect: > 100 mg/kg
Compound 3 gave a limit, no number; the forecaster's own chance of this, stated with the estimate: 85%; the middle value does not contradict the limit.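

Compound 3 gives a limit and not a number, as do compound 1 and compound 2, so no step to compound 3 from either of them can be read in this assay: the limit of > 100 mg/kg in this assay, at which 3 of the 3 values shown sit.

The compounds shown leave open whether 5-methyl-1H-imidazol-1-yl in place of pyrrolidin-1-yl, or ethoxy in place of methyl on a carbonyl carbon, changes the dose needed at all.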